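Chloro in place of bromo in compound 2

A few compounds are considered here, and "the series" means these few. Any claim that something is new, unique, unknown or untested is made for them only; others in the source may bear on it.

Compound 1 `O=S(=O)(/C=C/c1ccc(Cl)c(Cl)c1)Cc1ccc(Nc2ncnc3ccccc23)cc1`: 11000 nM
Compound 2 `O=S(=O)(/C=C/c1ccc(Br)cc1)Cc1ccc(Nc2ncnc3ccccc23)cc1`: > 100000 nM
Compound 3 `O=S(=O)(/C=C/c1ccc(Cl)cc1)Cc1ccc(Nc2ncnc3ccccc23)cc1`: not yet measured

In a functional assay on HT-29 cells (Homo sapiens) (on this read-out lower numbers stand for stronger inhibition of growth and higher numbers for weaker inhibition of growth), compound 2 gives > 100000 nM, which is a limit and not a number. Compound 3 differs from it by chloro in place of bromo on an aromatic carbon. Within the data shown here, one measured step bears on this position, an at least 9.0-fold higher number from compound 1 to compound 2 (0.95 log units; beyond the scatter), and it lies beyond the scatter. Compound 1 also carries chloro and gives 11000 nM, so a modest move toward lower numbers is expected. The expected move is an at least 2.5-fold lower number from compound 2 to compound 3 (0.39 log units; beyond the scatter). For compound 3 the estimate is 40000 nM, with an expected range of 12000 nM to 100000 nM.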

Compound 3, concentration for 50% growth inhibition: 73000 nM
Compound 3: the middle estimate sits 1.8-fold (0.26 log units) below what was measured; low and high end bracket the measured number.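

In this assay, chloro in place of bromo gives an at least 1.3-fold lower number from compound 2 to compound 3 (0.13 log units; that floor lies within the scatter), so the exchange of one halogen for the other shows no firm gain. That step is only a floor, because compound 2 stands at a limit and not at a number: the limit of > 100000 nM in this assay, at which 1 of the 3 values shown sits.

Hydrogen in place of the second chloro gives a 6.6-fold higher number from compound 1 to compound 3 (0.82 log units; beyond the scatter), so the clear move among these compounds comes from that chloro and not from the choice of halogen para to a large group.

As far as these compounds go, whether an amine, a methoxy group or a carboxylic acid at this position would lower the number stays open.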